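Carboxy to Ethoxycarbonyl on the Shared Core

The compounds below may be only part of what the source reports. "The series", "measured", "known", "first", "only" and "open" are said of these compounds alone.

Measured so far in a functional assay on the whole organism (strain Sprague-Dawley) for inhibition, with Rattus norvegicus as the target, with a stated time of 10 min; a higher number here means that more compound is needed for the effect, a lower number that less compound is needed:
- Compound 1 `O=C(O)c1cnc(-c2ccc(C(F)(F)F)cc2)[nH]c1=O` gives > 5 mg/kg as a limit
- Compound 2 `COc1ccc(-c2ncc(C(=O)O)c(=O)[nH]2)cc1` gives > 5 mg/kg as a limit
- Compound 3 `COc1ccc(-c2ncc(C(=O)O)c(=O)[nH]2)c(OC)c1` gives 5 mg/kg as a number

Compound 2 has no number in this assay and stands only at the limit of > 5 mg/kg in this assay, at which 2 of the 3 values shown sit, in the series. Compound 4 `CCOC(=O)c1cnc(-c2ccc(OC)cc2)[nH]c1=O` is made from it by one change, ethyl in place of hydrogen on an oxygen next to a carbonyl group with ethyl in place of hydrogen on an oxygen next to a carbonyl group, so that carboxy becomes ethoxycarbonyl. Within the data shown here, two measured steps touch compound 2. They are a step that the two limits leave unreadable from compound 1 to compound 2 and a number no higher from compound 2 to compound 3 (the limit leaves the size open) and neither has a readable size. Among the measured compounds shown here, both were changes on an aromatic carbon, and no measured step concerns this oxygen, so neither offers a size to carry over. The expectation rests on the limit of compound 2 (> 5 mg/kg) alone. The estimate is a step that the limit leaves unreadable from compound 2 to compound 4 in size, so no clear drop in the dose is expected. For compound 4 the estimated value is 10 mg/kg with an expected range from 5 mg/kg to 30 mg/kg and a good chance that the assay reports only a limit.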

Compound 4, dose for 50% inhibition: 30 mg/kg
Beside the measured number, compound 4's estimate is 3.0-fold (0.48 log units) below it; measured number inside the range.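

No size can be read for the change from compound 2 to compound 4. Compound 2 stands only at a limit, > 5 mg/kg. The compounds shown leave open how far ethoxycarbonyl in place of carboxy shifts the dose, with no pair carrying two numbers across that change.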